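Swapping Phenoxy for Trifluoromethoxy: Expected Effect on Cytotoxicity

The source may hold more compounds than are shown below. What is called first, only, known or untested is meant among the compounds shown, and "the series" means these compounds.

Compound 1 `COc1cc(OC)cc(-n2cc(-c3ccc(OC)c(OC)c3)nn2)c1`: > 1000 nM
Compound 2 `COc1ccc(-c2cn(-c3ccc(OC)c(O)c3)nn2)cc1O`: > 10000 nM
Compound 3 `COc1cc(OC)cc(-c2cn(-c3ccc(Oc4ccccc4)cc3)nn2)c1`: > 10000 nM

In a functional assay on MDA-MB-231 cells (Homo sapiens) for cytotoxicity, read by MTT assay (on this read-out lower numbers stand for stronger inhibition and higher numbers for weaker inhibition), compound 1 gives only a limit, > 1000 nM. Compound 2 likewise gives only a limit, > 10000 nM. Compound 3 also stops at a limit, > 10000 nM. None of the three therefore yields a number: one value sits at the limit of > 1000 nM in this assay, at which 1 of the 3 values shown sits, and two at the limit of > 10000 nM in this assay, at which 2 of the 3 values shown sit, and compound 3 stands among the latter, with no measured activity to anchor it.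

Compound 4 `COc1cc(OC)cc(-c2cn(-c3ccc(OC(F)(F)F)cc3)nn2)c1` differs from compound 3 in one place: trifluoromethyl in place of phenyl on an oxygen on an aromatic ring. For the measured compounds named here, no pair among the measured compounds differs by a single change, so the size of such a step is unknown here. With every shown value at a limit, compound 4 is expected to stay near the limit, and the step of a number no higher from compound 3 to compound 4 (the limit leaves the size open) is expected to be none beyond the scatter. Compound 4 is estimated at 10000 nM, within 3000 nM to 50000 nM.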

Compound 4, half-maximal inhibitory concentration: > 1000 nM
Compound 4 ended at the assay's limit; the forecaster's own chance of this, stated with the estimate: 65%; the middle value lies beyond the limit too.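

Compound 3 and compound 4 both stop at limits rather than numbers, so the step between them cannot be read. The compounds shown leave open whether phenoxy to trifluoromethoxy changes cytotoxicity at all.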